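Adding a Fourth Ring Nitrogen: Expected Effect on Potency

A few compounds are considered here, and "the series" means these few. Any claim that something is new, unique, unknown or untested is made for them only; others in the source may bear on it.

Compound 1 `CCCCCNC(=O)Nc1c(OCCCn2cnc(-c3ccccc3)c2)cccc1N(C)C`: 31 nM
Compound 2 `CCCCCNC(=O)Nc1c(OCCCn2ncc(-c3ccccc3)n2)cccc1N(C)C`: 32 nM

Both compounds were tested in an assay for inhibition of acyl-CoA:cholesterol acyltransferase (Oryctolagus cuniculus), using microsomes; a lower number here means a stronger inhibitor, a higher number a weaker inhibitor. Compound 2 shows the larger of the two numbers, but a 1.0-fold higher number from compound 1 to compound 2 (0.01 log units; within the scatter) lies within the scatter, so the two compounds cannot be told apart on this assay. Compound 3 `CCCCCNC(=O)Nc1c(OCCCn2nnc(-c3ccccc3)n2)cccc1N(C)C` is the next member of the series and differs from compound 2 in one place: a group of 11 heavy atoms (7 carbon, 4 nitrogen; one five-membered aromatic ring with 4 hetero atoms, one six-membered aromatic ring of carbon only) in place of a group of 11 heavy atoms (8 carbon, 3 nitrogen; one five-membered aromatic ring with 3 hetero atoms, one six-membered aromatic ring of carbon only), on a saturated chain carbon, three bonds along the chain from an oxygen on an aromatic ring. Among the compounds with values here, the only measured step that bears on this change is the one from compound 1 to compound 2, where one ring carbon was likewise exchanged for a nitrogen in the same five-membered ring, and the number did not move. On that basis, compound 3 is expected to show a 1.3-fold higher number from compound 2 to compound 3 (0.10 log units; within the scatter), with no step beyond the scatter. The estimate for compound 3 in this assay is 40 nM, expected to fall between 15 nM and 110 nM.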

Compound 3, half-maximal inhibitory concentration: 23 nM
Beside the measured number, compound 3's estimate is 1.7-fold (0.24 log units) above it, within the range that was stated.
By their numbers in this assay, from the lowest: compounds 3, 1 and 2 (each within the scatter of the next).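

In this assay, the new 5-phenyl-2H-tetrazol-2-yl group gives a 1.4-fold lower number from compound 2 to compound 3 (0.14 log units; within the scatter) and, set against the 4-phenyl-1H-imidazol-1-yl group, gives a 1.3-fold lower number from compound 1 to compound 3 (0.13 log units; within the scatter) as well. The earlier compounds shown here offered a single comparison, whereas compounds 1, 2 and 3 now form a series of three in which the five-membered aromatic ring takes on more nitrogen with no step beyond the scatter. So at this position, on a saturated chain carbon, the exact ring nitrogen count makes no measurable difference here, and nothing available explains why.

The compounds shown leave open whether the phenyl ring on the five-membered ring is needed, since every compound here carries it. They also leave open how a carboxylic acid or an amine in place of the whole ring group, or a longer chain leading to it, would fare.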